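The source may report more compounds than this note shows. Statements on the series, on what has been measured and on what is new or still open speak of the compounds shown alone.

Measured compounds:
- compound 1 `CC(NC(=O)/C=C/c1ccc(NC(=O)Nc2ccc(Cl)c(C(F)(F)F)c2)cc1)c1ccccc1` gives 1060 nM in a functional assay on HT-29 cells (Homo sapiens) for inhibition, read by MTT assay, with a stated time of 120 h; on this read-out higher numbers stand for weaker inhibition and lower numbers for stronger inhibition
- compound 2 `CC(NC(=O)c1ccc(-c2ccc(NC(=O)Nc3cc(C(F)(F)F)ccc3Cl)cc2)cc1)c1ccccc1` gives 6570 nM
- compound 3 `CC(NC(=O)/C=C/c1ccc(NC(=O)Nc2cc(C(F)(F)F)ccc2Cl)cc1)c1ccccc1` gives 4190 nM

Compound 1 and compound 3 share a core and differ only in the aryl group on the urea nitrogen, (4-chloro-3-(trifluoromethyl)phenyl in place of 2-chloro-5-(trifluoromethyl)phenyl on an amide-type nitrogen); this change gives a 4.0-fold lower number from compound 3 to compound 1 (0.60 log units; beyond the scatter), a clear gain in inhibition. Compound 2 is built on a different core; how its core differs from that of compound 3 is not broken down here, and its value sits within the scatter of that of compound 3, so no order between them is claimed.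

Compound 4 `CC(NC(=O)c1ccc(-c2ccc(NC(=O)Nc3ccc(Cl)c(C(F)(F)F)c3)cc2)cc1)c1ccccc1` is not yet measured. It relates to compound 2 exactly as compound 1 relates to compound 3, by the same change, (4-chloro-3-(trifluoromethyl)phenyl in place of 2-chloro-5-(trifluoromethyl)phenyl on an amide-type nitrogen), on the same amide-type nitrogen. The expectation is that the step from compound 2 to compound 4 in this assay resembles the step seen earlier, because a 4.0-fold lower number from compound 3 to compound 1 (0.60 log units; beyond the scatter) was observed with the other core; that step from compound 2 to compound 4 is estimated at a 3.7-fold lower number from compound 2 to compound 4 (0.56 log units; beyond the scatter), with some caution since the cores differ. Compound 4 is therefore expected to give about 1800 nM, likely between 600 nM and 5000 nM.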

Compound 4, half-maximal inhibitory concentration: 5960 nM
Compound 4: middle estimate off by 3.3-fold (0.52 log units), on the low side; the measured number lies above the stated range.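

On the core of compound 2, the change to 4-chloro-3-(trifluoromethyl)phenyl on the amide-type nitrogen gives a 1.1-fold lower number from compound 2 to compound 4 (0.04 log units; within the scatter) in this assay, so compound 2 and compound 4 cannot be put in order. The gain seen on the core of compound 1 therefore does not carry over in full size to this second core, and the two steps really do differ: the same change on two cores in this assay, a 4.0-fold lower number (0.60 log units; beyond the scatter) from compound 3 to compound 1 and a 1.1-fold lower number (0.04 log units; within the scatter) from compound 2 to compound 4, 3.6-fold (0.55 log units) apart, beyond the scatter of two such steps

This does not show why the two cores respond differently, and two cores are too few to predict the size of the step on a third core.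

The compounds shown leave open whether the gap between the two steps would remain with a nitrile or a fluorine in place of the chlorine on the aryl ring, or with an amine or a carboxylic acid added to the far end of the molecule. They also leave open whether the same pattern would appear in other cell lines.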